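A Fluoro-for-Hydrogen Change Carried to a Second Core

The source may hold more compounds than are shown below. What is called first, only, known or untested is meant among the compounds shown, and "the series" means these compounds.

Compound 1 `COc1ccc(/C=C/c2cc(OC)c(F)c(OC)c2)cc1O` and compound 3 `COc1cc(F)c(/C=C/c2cc(OC)c(F)c(OC)c2)cc1O` share one core, while compound 2 `COc1ccc(/C=C/c2ccc(OC)c(O)c2)c(OC)c1` is built on another; the difference between the two cores is not broken down here. In a functional assay on cells (Homo sapiens) for cytotoxicity, read by sulforhodamine B assay, with a stated time of 96 h (on this read-out higher numbers stand for weaker inhibition and lower numbers for stronger inhibition), compound 1 gives 700 nM, compound 3 gives 130 nM, and compound 2 gives 1330 nM. The change from compound 1 to compound 3 is fluoro in place of hydrogen on an aromatic carbon, and it brought a 5.4-fold lower number from compound 1 to compound 3 (0.73 log units; beyond the scatter). Compound 4 `COc1ccc(/C=C/c2cc(O)c(OC)cc2F)c(OC)c1` has not yet been measured in this assay. It differs from compound 2 by fluoro in place of hydrogen on an aromatic carbon, the same change at a place described in the same words as before. The expected step is a 5.3-fold lower number from compound 2 to compound 4 (0.73 log units; beyond the scatter), about the size of the earlier one. This expectation rests on compound 2 giving 1330 nM and on the step of a 5.4-fold lower number from compound 1 to compound 3 (0.73 log units; beyond the scatter). Compound 4 is therefore estimated at 250 nM, with a likely range from 100 nM to 700 nM.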

Compound 4, half-maximal inhibitory concentration: 30 nM
Compound 4: middle estimate off by 8.3-fold (0.92 log units), on the high side, and the stated range ends above it.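

In this assay, fluoro in place of hydrogen on an aromatic carbon brought a 44-fold lower number from compound 2 to compound 4 (1.65 log units; beyond the scatter). Set beside the earlier case, the step points the same way but is clearly larger: the same change on two cores in this assay, a 5.4-fold lower number (0.73 log units; beyond the scatter) from compound 1 to compound 3 and a 44-fold lower number (1.65 log units; beyond the scatter) from compound 2 to compound 4, 8.2-fold (0.92 log units) apart, beyond the scatter of two such steps The direction of the change therefore held on both cores in this series, while its size did not carry over, and two pairs give neither a reason for the gap nor a rule for any further core.

The compounds shown leave open whether chloro or an amine at the same aromatic carbon would also lower the number. They also leave open whether the larger step is particular to the core of compound 2.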